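This account rests on a few compounds, and the source may have more. Where it says the series, first, only, none or still open, it means among the compounds named here.

Measured in a functional assay on MDA-MB-435 cells (Homo sapiens) for cytotoxicity, read by MTT assay, with a stated time of 72 h; a higher number here means a weaker inhibitor, a lower number a stronger inhibitor:

Compound 1 `CS(=O)(=O)Oc1c(C(=O)NCc2ccc(F)cc2)nc(Br)c2cccnc12`: > 20000 nM, a limit of the assay rather than a number.
Compound 2 `O=C(NCc1ccc(F)cc1)c1nc(NCCO)c2cccnc2c1O`: > 20000 nM, also a limit.
Compound 3 `N[C@H]1CC[C@H](Nc2c(C(=O)NCc3ccc(F)cc3)nc(N3CCCCC3)c3cccnc23)CC1`: 5000 nM.

Compound 1 stands at the limit of this assay, where no number is obtained; (the limit of > 20000 nM in this assay, at which 2 of the 3 values shown sit). Compound 3 is the only one of the three that gives a measured number. Compound 4 `NCCNc1c(C(=O)NCc2ccc(F)cc2)nc(Br)c2cccnc12` is compound 1 with one change: (2-aminoethyl)amino in place of (methylsulfonyl)oxy on an aromatic carbon. For the measured compounds named here, no two measured compounds differ in just one place, so the size of this step has no direct precedent among them. Compound 3 gives a number while carrying an amine in a chain on the core, whereas compound 2, with a hydroxyl-ended chain and no bromo group, stays at the limit. Compound 4 keeps the bromo group of compound 1 and adds an amine-ended chain, so the expectation is a modest move toward stronger inhibition, an at least 1.6-fold lower number from compound 1 to compound 4 (0.22 log units; that floor lies within the scatter), with a real chance that only a limit is reported. Compound 4 is expected at 12000 nM, in the range 3000 nM to 40000 nM.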

Compound 4, half-maximal inhibitory concentration: 12000 nM
Compound 4: middle estimate and measured number agree at the digits printed; measured number inside the range.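

On this aromatic carbon, para to a bromo group, (2-aminoethyl)amino in place of (methylsulfonyl)oxy brings the core of compound 1 from a limit to a measured number in this assay, giving an at least 1.6-fold lower number from compound 1 to compound 4 (0.22 log units; that floor lies within the scatter). This is the first single-place change among the compounds shown, and it gives a floor on the size of the step rather than an exact size. Compound 1 gives a limit of the assay and not a number: the limit of > 20000 nM in this assay, at which 2 of the 4 values shown sit.

The entering group differs from the leaving one in several ways at once, including its hydrogen-bond donors, and this single step cannot separate them. From the compounds shown here alone, how a longer chain such as (3-aminopropyl)amino, or a dimethylamino group at the chain end, would read at this position in this assay remains open.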